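Replacing a chlorobenzyl ether with a methylbenzyl ether

A few compounds are considered here, and "the series" means these few. Any claim that something is new, unique, unknown or untested is made for them only; others in the source may bear on it.

Measured compounds:
compound 1, `Cc1ccc(NC(=S)NC(=O)c2ccc(OCc3cccc(Cl)c3Cl)cc2)cc1-c1nc2ccccc2[nH]1`, > 100000 nM
compound 2, `O=C(NC(=S)Nc1ccc(Cl)c(-c2nc3ccccc3[nH]2)c1)c1ccc(OCc2ccc(Cl)cc2Cl)cc1`, 50200 nM
compound 3, `Cc1ccc(NC(=O)NC(=O)c2ccc(OCc3cccc(Cl)c3)cc2)cc1-c1nc2ccccc2[nH]1`, 16000 nM

Three compounds sharing an acyl urea or acyl thiourea core have been tested in a functional assay on SW-620 cells (Homo sapiens) for inhibition, read by MTT assay, with a stated time of 48 h; a higher number here means a weaker inhibitor, a lower number a stronger inhibitor. Compound 1 gives only a limit in this assay, > 100000 nM, so no number is known for it (the limit of > 100000 nM in this assay, at which 1 of the 3 values shown sits). Compound 2 gives 50200 nM. Compound 3, the acyl urea bearing a (3-chlorobenzyl)oxy group, gives 16000 nM, the lowest of the two numbers shown, and its gap to compound 2 lies beyond the usual scatter.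

Compound 4, `Cc1ccc(COc2ccc(C(=O)NC(=O)Nc3ccc(C)c(-c4nc5ccccc5[nH]4)c3)cc2)cc1`, is not yet measured. It differs from compound 3 in one place: 4-methylphenyl in place of 3-chlorophenyl on a saturated chain carbon bound to an oxygen on an aromatic ring. Among the measured compounds shown here, no step between measured compounds isolates this change, so the expected effect rests on compound 3 alone. The step from compound 3 to compound 4 is expected to be small, within the scatter, with no clear direction, as a 1.3-fold higher number from compound 3 to compound 4 (0.10 log units; within the scatter). Compound 4 is therefore estimated at 20000 nM in this assay, between 6000 nM and 80000 nM.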

Compound 4, half-maximal inhibitory concentration: 26000 nM
Compound 4: the middle estimate sits 1.3-fold (0.11 log units) below what was measured; measured number inside the range.
By their numbers in this assay, from the lowest: compounds 3, 4 and 2 (each within the scatter of the next, the first and the last beyond it). At a limit, above all of these: compound 1.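

In this assay, among the compounds shown here, putting 4-methylphenyl in place of 3-chlorophenyl on a saturated chain carbon bound to an oxygen on an aromatic ring gives a 1.6-fold higher number from compound 3 to compound 4 (0.21 log units; within the scatter), the first step in this set that isolates a single change. On this acyl urea, then, the (3-chlorobenzyl)oxy and (4-methylbenzyl)oxy groups cannot be told apart in this assay, and the chlorine is not required to keep the number within the scatter of compound 3. No measurement shown bears on a cause for this result.

The step swaps chlorine for methyl and also changes where the substituent sits on the ring, so a 3-methylbenzyl or a 4-chlorobenzyl ether on the same core would be needed to separate those two changes. From the compounds shown here alone, it also remains open how an unsubstituted benzyl ether or a methoxy group on this ring would read, and what the sulfur of the acyl thiourea contributes, since compound 1 and compound 2 each differ from the acyl ureas in more than one place.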